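Chain-extended ether analogue in the aldehyde dehydrogenase series

This account rests on a few compounds, and the source may have more. Where it says the series, first, only, none or still open, it means among the compounds named here.

Measured compounds:
compound 1 `COCc1ccc(-n2c(SC(C)c3ccccc3)nc3c(cnn3C)c2=O)cc1`: 65%
compound 2 `CC(Sc1nc2c(cnn2C)c(=O)n1-c1ccc(CN)cc1)c1ccccc1`: 47%

In an assay on isolated protein for inhibition of aldehyde dehydrogenase 1A1 (Homo sapiens), tested at 5 uM (a lower number here means less inhibition, a higher number more inhibition at the concentration tested (going by the name of the read-out)), compound 1 gives 65% and compound 2 gives 47%. For the measured compounds named here, compound 2 stands lowest of the two, with compound 1 its only neighbour. Going by the values given here, the one measured step, a number 18 percentage points lower from compound 1 to compound 2 (beyond the scatter), arose from amino in place of methoxy on a saturated chain carbon bound to an aromatic carbon.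

Compound 3 `COCCc1ccc(-n2c(SC(C)c3ccccc3)nc3c(cnn3C)c2=O)cc1` is not yet measured. It differs from compound 2 by methoxymethyl in place of amino on a saturated chain carbon bound to an aromatic carbon. This change returns an ether in place of the amine, so the earlier step bears on it in reverse, though the chain is now longer. A rise in this assay is expected, estimated at a number 13 percentage points higher from compound 2 to compound 3 (beyond the scatter), giving compound 3 an expected 60% within 40% to 80%.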

Compound 3, a percentage reported as inhibition, at one concentration (the size of the read-out at that concentration, not a potency): 27%
Compound 3: middle estimate off by 33 percentage points, on the high side, outside the stated range (below it).
By their numbers in this assay, from the lowest: compound 3; then compound 2; then compound 1.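

In this assay, the ether does not restore inhibition at this saturated chain carbon bound to an aromatic carbon: a number 20 percentage points lower from compound 2 to compound 3 (beyond the scatter), so the earlier amino step does not simply reverse once the chain is longer. Against the shorter ether the loss is larger, a number 38 percentage points lower from compound 1 to compound 3 (beyond the scatter), so within these two ethers the 2-methoxyethyl group reads well under the methoxymethyl group. Nothing available accounts for this drop.

Open, on these data alone, is whether a longer chain such as 3-methoxypropyl lowers the number further. Also open, as far as these compounds go, is whether 2-aminoethyl at this place tracks the ether or the amine.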